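Microsomal stability notes on the shared-core series

A few compounds are considered here, and "the series" means these few. Any claim that something is new, unique, unknown or untested is made for them only; others in the source may bear on it.

Compound 1 `COc1nn2cc(-c3cc4ccc(OCc5ccccc5)cc4o3)nc2s1`: 68%
Compound 2 `COc1cc(OCc2cccc(C#N)c2)c2cc(-c3cn4nc(OC)sc4n3)oc2c1`: "not determined" (no result reported)
Compound 3 `COc1cc(OC)c2cc(-c3cn4nc(OC)sc4n3)oc2c1`: 70%

In an ADME assay on microsomes from liver (Rattus norvegicus) for metabolic stability, with a stated time of 10 min (a higher number here means that more of the compound is left, a lower number that less of the compound is left), compound 1 gives 68% and compound 3 gives 70%; these two values lie within the usual scatter of each other. In this assay compound 2 gives "not determined" (no result reported), so it offers no anchor of its own. Compound 4 `COc1cc(OCc2cccc(Sc3ccccc3)c2)c2cc(-c3cn4nc(OC)sc4n3)oc2c1` differs from compound 2 by phenylsulfanyl in place of cyano on an aromatic carbon. Among the compounds with values here, no measured pair follows that change, so the size of the step is open; a moderate fall in this assay is expected rather than none beyond the scatter, and the two measured values of compound 1 and compound 3 sit close together and leave room downward. Compound 4 is expected to give 50% in this assay, with a range from 25% to 75%.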

Compound 4, percent of the compound remaining: 45%
Estimate against measurement, compound 4: 5 percentage points above; the measured number falls inside the stated range.
By their numbers in this assay, from the lowest: compound 4; then compounds 1 and 3 (each within the scatter of the next).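

In this assay compound 4 gives 45% while compound 2 gives "not determined" (no result reported) so no new step can be read between them. Nothing shown here bears on a cause for the result.

Left open is how far phenylsulfanyl in place of cyano shifts the percent of compound remaining.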